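Chlorine Placement on the Pendant Phenyl of Compound 3

The source may report more compounds than this note shows. Statements on the series, on what has been measured and on what is new or still open speak of the compounds shown alone.

Measured compounds:
compound 1 `Cc1cccc(-n2cc(-c3ccc(NS(=O)(=O)c4c[nH]c(=O)[nH]c4=O)cc3)nn2)c1` 6960 nM
compound 2 `O=c1[nH]cc(S(=O)(=O)Nc2ccc(-c3cn(-c4ccc(F)cc4)nn3)cc2)c(=O)[nH]1` 9720 nM
compound 3 `O=c1[nH]cc(S(=O)(=O)Nc2ccc(-c3cn(-c4cccc(Cl)c4)nn3)cc2)c(=O)[nH]1` 2310 nM

Three compounds share one core and differ only in the phenyl carried on an aromatic nitrogen. In a functional assay on A549 cells (Homo sapiens) for antiproliferative activity, read by MTT assay, with a stated time of 24 h (a lower number here means a stronger inhibitor, a higher number a weaker inhibitor), compound 3 gives the lowest number of the three: the nearest is compound 1 at 6960 nM, a step of a 3.0-fold lower number from compound 1 to compound 3 (0.48 log units; beyond the scatter); the furthest is compound 2 at 9720 nM, a step of a 4.2-fold lower number from compound 2 to compound 3 (0.62 log units; beyond the scatter). Compound 1 and compound 2 sit within the scatter of each other (a 1.4-fold higher number from compound 1 to compound 2 (0.15 log units; within the scatter)).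

Compound 4 `O=c1[nH]cc(S(=O)(=O)Nc2ccc(-c3cn(-c4ccc(Cl)cc4)nn3)cc2)c(=O)[nH]1` is not yet measured. It differs from compound 3 in one place: 4-chlorophenyl in place of 3-chlorophenyl on an aromatic nitrogen. Going by the values given here, no measured pair moves a chlorine from one ring carbon to another, so no step bears on this change directly. The steps that touch the phenyl either swap methyl for chloro at the same place or change both the substituent and its place together, and those run from within the scatter to modest. The expectation for compound 4 in this assay is therefore a small step, a 1.7-fold higher number from compound 3 to compound 4 (0.24 log units; within the scatter), toward a higher number, and possibly none beyond the scatter. Compound 4 is estimated at 4000 nM, within 1500 nM to 12000 nM.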

Compound 4, half-maximal inhibitory concentration: 1210 nM
For compound 4 the middle estimate is 3.3-fold (0.52 log units) above the measured one; the whole stated range lies above it.
By their numbers in this assay, from the lowest: compounds 4 and 3 (each within the scatter of the next); then compounds 1 and 2 (each within the scatter of the next).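

Moving the chlorine from one ring carbon to another, a change the earlier compounds could not isolate, gives a 1.9-fold lower number from compound 3 to compound 4 (0.28 log units; within the scatter) in this assay, so the 3-chlorophenyl and 4-chlorophenyl compounds cannot be told apart in this assay. Going by these compounds alone, compound 4 also provides the first comparison of two halogens on the same ring carbon, with chloro in place of fluoro giving an 8.0-fold lower number from compound 2 to compound 4 (0.90 log units; beyond the scatter). The comparison with the 3-methylphenyl compound gives a 5.8-fold lower number from compound 1 to compound 4 (0.76 log units; beyond the scatter), so with compound 3 also beyond the scatter from compound 1 and compound 2, both chlorophenyl compounds stand apart from the methyl and fluoro compounds, and none of the four goes against this.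

Nothing available here accounts for these differences in cellular activity. The compounds shown leave open whether the pattern extends to other groups on the pendant phenyl, such as bromo, methoxy or nitrile in place of the chlorine, and how those groups would compare with compound 3 and compound 4.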